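This account rests on a few compounds, and the source may have more. Where it says the series, first, only, none or still open, it means among the compounds named here.

Among the measured compounds shown here, in a functional assay on HeLa cells (Homo sapiens) for inhibition (a higher number here means a weaker inhibitor, a lower number a stronger inhibitor), compound 1 (`O=C(O)CSC(CC(=O)c1ccccc1)C(=O)O`) gives 15000 nM, the highest of the two numbers measured so far. Compound 2 (`Cc1ccc(C)c(C(=O)CC(SCC(=O)O)C(=O)O)c1`) gives 2680 nM, a lower number by a gap beyond the usual scatter, so compound 1 is the weaker inhibitor of the pair.

Compound 3 (`O=C(O)CSC(CC(=O)c1ccc(F)cc1)C(=O)O`) has not yet been measured. It departs from compound 1 in a single place, fluoro in place of hydrogen on an aromatic carbon of a six-membered aromatic ring of carbon only, para to a large group.

For the measured compounds named here, no measured pair in this small set shows the effect of such a single change, so any forecast rests on thin evidence. Going by the values given here, the only hint is that compound 2, at 2680 nM, shows that a lower number than that of compound 1 can be reached. In this assay a small shift toward a lower number is therefore expected, with the estimated step of a 1.7-fold lower number from compound 1 to compound 3 (0.22 log units; within the scatter) about the size of the scatter. For compound 3 the expected value is 9000 nM, with an estimated range from 4000 nM to 20000 nM.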

Compound 3, half-maximal inhibitory concentration: 20700 nM
Compound 3: middle estimate off by 2.3-fold (0.36 log units), on the low side; measured number above the stated range.
By their numbers in this assay, from the lowest: compound 2; then compounds 1 and 3 (each within the scatter of the next).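

Fluoro in place of hydrogen on an aromatic carbon, para to a large group, gives the first single change that can be read in this assay, with a 1.4-fold higher number from compound 1 to compound 3 (0.14 log units; within the scatter). Compounds 1 and 3 therefore cannot be told apart in this assay, and on the core of compound 1 this one replacement gives no sign of a stronger or a weaker inhibitor. Among the compounds shown here, this is what the earlier compounds could not show, since neither of them formed a single-change pair with another, and the finding covers only this one group at this one place on the ring. No measurement at hand bears on why the two numbers stand so close.

The compounds shown leave open whether a different group in the same place, such as a chloro group, a methoxy group or an amine, would give a step beyond the scatter. They also leave open whether fluoro on another carbon of the same aromatic ring would behave as it does here.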